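The compounds below may be only part of what the source reports. "The series", "measured", "known", "first", "only" and "open" are said of these compounds alone.

Measured so far:
compound 1 `COCCNC(=O)c1cc2cccc(OC)c2oc1=N`: 43%
compound 2 `COc1cccc2cc(C(=O)Nc3c(C#N)ncn3-c3ccccc3)c(=N)oc12`: 9%
compound 3 `COc1ccc(-n2cnc(C#N)c2NC(=O)c2cc3cccc(OC)c3oc2=N)cc1`: 5%

In an assay on HEK293 cells for displacement of a labelled ligand from adenosine receptor A2b (Homo sapiens), read by scintillation counting, with a stated time of 30 min, tested at 10 uM (a lower number here means less inhibition, a higher number more inhibition at the concentration tested (going by the name of the read-out)), compound 1 gives 43%, the highest of the three numbers; compound 2 gives 9% and compound 3 gives 5%, both beyond the scatter below compound 1. Within the data shown here, the only single-point step among the measured compounds, a number 4 percentage points lower from compound 2 to compound 3 (within the scatter), concerns methoxy in place of hydrogen on an aromatic carbon and says nothing about the amide substituent.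

Compound 4 `CCC(CO)NC(=O)c1cc2cccc(OC)c2oc1=N` differs from compound 1 by 1-(hydroxymethyl)propyl in place of 2-methoxyethyl on an amide-type nitrogen. Among the measured compounds shown here, no measured step touches this part of the shared core, so the expectation rests on compound 1 alone, with a wide range. Compound 4 is expected to give about 40% in this assay, between 18% and 62%. The step is thus estimated as a number 3 percentage points lower from compound 1 to compound 4 (within the scatter), no change beyond the scatter.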

Compound 4, a percentage reported as inhibition, at one concentration (the size of the read-out at that concentration, not a potency): 39%
Beside the measured number, compound 4's estimate is 1 percentage points above it; low and high end bracket the measured number.
By their numbers in this assay, from the lowest: compounds 3 and 2 (each within the scatter of the next); then compounds 4 and 1 (each within the scatter of the next).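

The earlier compounds shown here gave no step at the amide-type nitrogen; here, swapping 2-methoxyethyl for 1-(hydroxymethyl)propyl gives a number 4 percentage points lower from compound 1 to compound 4 (within the scatter) in this assay. So a chain with a hydrogen-bond donor can replace one without a donor at this position with no change beyond the scatter. Nothing shown explains why the reading holds across this change. Still open, from the compounds shown here alone, is whether an amine, a carboxylic acid or a longer chain on this nitrogen would leave the number where it stands. Also open, going by these compounds, is whether a ring in this place would do the same.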